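Furan-2-yl in Place of a Dibromophenol

This account rests on a few compounds, and the source may have more. Where it says the series, first, only, none or still open, it means among the compounds named here.

In a functional assay on HepG2 cells (Homo sapiens) for cytotoxicity, read by MTT assay, with a stated time of 48 h (on this read-out higher numbers stand for weaker inhibition and lower numbers for stronger inhibition), compound 1 `O=C(CSc1nnc(-c2ccncc2)o1)N/N=C/c1ccc(O)cc1` gives 5510 nM, compound 2 `O=C(CSc1nnc(-c2ccncc2)o1)N/N=C/c1cc(Br)ccc1O` gives 6490 nM and compound 3 `O=C(CSc1nnc(-c2ccncc2)o1)N/N=C/c1cc(Br)cc(Br)c1O` gives 6540 nM. Compound 3 therefore stands within the scatter of both other compounds. Compound 4 `O=C(CSc1nnc(-c2ccncc2)o1)N/N=C/c1ccco1` differs from it at one place: furan-2-yl in place of 3,5-dibromo-2-hydroxyphenyl on a carbon with a double bond to nitrogen. In words, furan-2-yl sits in place of 3,5-dibromo-2-hydroxyphenyl on a carbon with a double bond to nitrogen. The nearest evidence is a 1.2-fold higher number from compound 1 to compound 2 (0.07 log units; within the scatter), a 1.2-fold higher number from compound 1 to compound 3 (0.07 log units; within the scatter) and a 1.0-fold higher number from compound 2 to compound 3 (0.00 log units; within the scatter), all within the scatter. None of these steps replaces the phenyl ring, so the evidence is indirect. The expected change is no larger than the scatter, an estimated 1.1-fold higher number from compound 3 to compound 4 (0.03 log units; within the scatter). Compound 4 is estimated at 7000 nM, within an expected range of 3000 nM to 16000 nM.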

Compound 4, half-maximal inhibitory concentration: 12500 nM
For compound 4 the middle estimate is 1.8-fold (0.25 log units) below the measured one; the range from low to high includes it.
By their numbers in this assay, from the lowest: compounds 1, 2, 3 and 4 (each within the scatter of the next, the first and the last beyond it).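

Among the compounds shown here, at this carbon with a double bond to nitrogen, furan-2-yl gives the first step beyond the scatter, though a modest one, and only against the 4-hydroxyphenyl compound (a 2.3-fold higher number from compound 1 to compound 4 (0.36 log units; beyond the scatter)); a higher number here means weaker inhibition. Against the brominated rings, the same change stays within the scatter (a 1.9-fold higher number from compound 3 to compound 4 (0.28 log units; within the scatter); a 1.9-fold higher number from compound 2 to compound 4 (0.28 log units; within the scatter)). No measurement offers an explanation for this step.

Furan-2-yl differs from the other groups in both its ring and its lack of a hydroxy group, so these two changes cannot be separated. Plain phenyl at this place would address that question.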